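Dichloropurine variants of a chloromethylbenzyl series in OVCAR-5 cells

The source may report more compounds than this note shows. Statements on the series, on what has been measured and on what is new or still open speak of the compounds shown alone.

Three compounds share one core, a chloropurine carrying a chloromethylbenzyl group, and differ only in where the chloromethyl sits on the benzyl ring. Compound 1 `ClCc1ccc(Cn2cnc3c(Cl)ncnc32)cc1` places it across the ring from the purine, compound 2 `ClCc1cccc(Cn2cnc3c(Cl)ncnc32)c1` and compound 3 `ClCc1ccccc1Cn1cnc2ncnc(Cl)c21` elsewhere. In a functional assay on OVCAR-5 cells (Homo sapiens) for cytotoxicity, read by sulforhodamine B assay, with a stated time of 48 h (on this read-out lower numbers stand for higher toxicity in this test and higher numbers for lower toxicity in this test), compound 1 gives 34700 nM, compound 2 gives 8910 nM and compound 3 gives 26900 nM. Compound 1 thus stands at the highest of the three numbers, but compound 3 lies within the usual scatter of it, so the two cannot be told apart; only compound 2 sits beyond the scatter, with the lower number.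

Compound 4 `ClCc1ccc(Cn2cnc3c(Cl)nc(Cl)nc32)cc1` is not yet measured. It keeps the benzyl pattern of compound 1 and differs from it by chloro in place of hydrogen on an aromatic carbon, placed between two ring nitrogen atoms, meta to a chloro group and to the fused ring and para to the fused ring. Among the compounds with values here, no pair in the set shows what a second chloro on the core does, so the size of the step in this assay is an open question; a step staying within the scatter, or a modest move in either direction, seems the most likely outcome. On that basis compound 4 is estimated at 25000 nM, within 8000 nM to 80000 nM, a step of a 1.4-fold lower number from compound 1 to compound 4 (0.14 log units; within the scatter).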

Compound 4, concentration lethal to 50% of the cells: 66100 nM
Compound 4: the middle estimate sits 2.6-fold (0.42 log units) below what was measured, within the range that was stated.
By their numbers in this assay, from the lowest: compound 2; then compounds 3, 1 and 4 (each within the scatter of the next, the first and the last beyond it).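

Within the data shown here, the pair of compound 1 and compound 4 is the first in the set to differ on the core rather than on the benzyl ring, and it gives a direct reading of chloro in place of hydrogen on an aromatic carbon between two ring nitrogen atoms. In this assay this change gives a 1.9-fold higher number from compound 1 to compound 4 (0.28 log units; within the scatter) and so cannot be told apart from no change at all: with the benzyl pattern of compound 1, this position takes the added chloro without a step that can be read as a gain or a loss of toxicity in this test. Nothing available bears on why the read-out behaves this way.

As far as these compounds go, whether the same chloro gives a similar step with the benzyl patterns of compound 2 and compound 3 remains open, since only the benzyl pattern of compound 1 is seen with and without it. Also open, from the compounds shown here alone, is what an amine, a methoxy group or a methyl group would do on this same aromatic carbon, where only hydrogen and chloro are seen so far.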